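The compounds below may be only part of what the source reports. "The series", "measured", "known", "first", "only" and "open" are said of these compounds alone.

Of the compounds shown here, three have so far been tested in a functional assay on DU-145 cells (Homo sapiens) for inhibition, read by trypan blue exclusion, with a stated time of 96 h; a higher number here means a weaker inhibitor of growth, a lower number a stronger inhibitor of growth. Compound 1, `Cc1ccc(S/C(=C/c2c[nH]c3ccccc23)C(=O)c2ccc(Br)cc2)cc1`, gives 10000 nM. Compound 2, `O=C(/C(=C\c1c[nH]c2ccccc12)Sc1ccc(Br)cc1)c1ccc(Br)cc1`, gives 1000 nM. Compound 3, `COc1ccc(/C=C(\C(=O)c2ccc(Cl)cc2)S(=O)(=O)c2ccc(Br)cc2)cc1O`, gives 10000 nM, level with compound 1 at the digits given, so that these two stand together at the highest number of the three, while compound 2 sits clearly lower. Compound 4, `COc1ccc(/C=C(\C(=O)c2ccc(Cl)cc2)S(=O)(=O)c2ccc(C)cc2)cc1O`, has not yet been tested.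

Compound 1 and compound 2 share one core and differ at a single place: methyl in place of bromo on an aromatic carbon. That change produced a 10-fold higher number from compound 2 to compound 1 (1.00 log units; beyond the scatter). Compound 3 and compound 4 differ in the same way: methyl in place of bromo on an aromatic carbon. Read one bond further out, the first pair goes from (4-bromophenyl)sulfanyl to (4-methylphenyl)sulfanyl and the second from (4-bromophenyl)sulfonyl to (4-methylphenyl)sulfonyl; the difference between the core of compound 2 and the core of compound 3 is not broken down here, so the two pairs show the same change set on two different cores.

The expectation for compound 4 rests on this single precedent and on the starting point of compound 3 at 10000 nM, already the highest number in the set. The step expected, a 3.0-fold higher number from compound 3 to compound 4 (0.48 log units; beyond the scatter), is estimated to run in the same direction as the earlier one but to be less certain, with a real chance that only a limit is reported. Compound 4 is therefore expected to give about 30000 nM, estimated to lie between 8000 nM and 100000 nM.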

Compound 4, concentration for 50% growth inhibition: 1000 nM
Beside the measured number, compound 4's estimate is 30-fold (1.48 log units) above it; measured number below the stated range.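

In this assay, methyl in place of bromo gave a 10-fold lower number from compound 3 to compound 4 (1.00 log units; beyond the scatter), so on this core the change goes the opposite way to a 10-fold higher number from compound 2 to compound 1 (1.00 log units; beyond the scatter) on the other core. Set side by side, the two results clearly disagree: the same change on two cores in this assay, a 10-fold higher number (1.00 log units; beyond the scatter) from compound 2 to compound 1 and a 10-fold lower number (1.00 log units; beyond the scatter) from compound 3 to compound 4, 100-fold (2.00 log units) apart, beyond the scatter of two such steps. This shows that the effect of the change cannot simply be carried from one core to the other in this series, since a result on one core predicted neither the direction nor the outcome on the other, but it does not show which of the differences between the two cores is responsible, and two pairs give no explanation for the split.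

The compounds shown leave open how each core responds to other groups in the same place, such as an amine, a carboxylic acid or a longer chain like butyl, and whether such groups would also behave differently on the two cores. They also leave open whether the opposite directions seen here would persist across further matched pairs built on these same two cores.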